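Widening the Sulfonamide Nitrogen on a Shared Core

A few compounds are considered here, and "the series" means these few. Any claim that something is new, unique, unknown or untested is made for them only; others in the source may bear on it.

Measured so far in an ADME assay on CHO cells (Cricetulus griseus) for cytotoxicity, read by MTT assay; on this read-out higher numbers stand for weaker inhibition and lower numbers for stronger inhibition:
compound 1, `CS(=O)(=O)c1cccc(Nc2ccc3nccc(-c4ccncc4)c3n2)c1` — > 50000 nM (a limit of the assay)
compound 2, `O=S(=O)(NCCO)c1cccc(Nc2ccc3nccc(-c4ccncc4)c3n2)c1` — 4000 nM
compound 3, `NS(=O)(=O)c1cccc(-c2ccc3nccc(-c4ccncc4)c3n2)c1` — 2000 nM

Compound 3 gives the lowest number of the two numbers that are not limits, and compound 2 sits nearest to it, within the usual scatter, so the two cannot be put in order. For compound 1 only a limit was reported (the limit of > 50000 nM in this assay, at which 1 of the 3 values shown sits). Compound 4, `O=S(=O)(c1cccc(-c2ccc3nccc(-c4ccncc4)c3n2)c1)N1CC[C@H](O)C1`, is not yet measured. Its change from compound 3 is 3-hydroxypyrrolidin-1-yl in place of amino on a sulfonyl sulfur.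

For the measured compounds named here, the one measured step in the set is an at least 12-fold lower number from compound 1 to compound 2 (1.09 log units; beyond the scatter). That step exchanges a methyl for a hydroxyalkylamino group on the sulfonyl sulfur, whereas the step to compound 4 keeps a nitrogen on the sulfur and only extends it into a hydroxylated ring, so the measured step bears on it indirectly at most. Compound 2, with its hydroxyalkyl substituent on the sulfonamide nitrogen, sits within the scatter of compound 3. The step expected from compound 3 to compound 4 in this assay is therefore small, a 1.5-fold higher number from compound 3 to compound 4 (0.18 log units; within the scatter), in no firm direction. Compound 4 is estimated at 3000 nM, within 1000 nM to 10000 nM.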

Compound 4, half-maximal inhibitory concentration: 9000 nM
For compound 4 the middle estimate is 3.0-fold (0.48 log units) below the measured one; low and high end bracket the measured number.
By their numbers in this assay, from the lowest: compounds 3 and 2 (each within the scatter of the next); then compound 4. At a limit, above all of these: compound 1.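

In this assay, going from sulfamoyl to (3-hydroxypyrrolidin-1-yl)sulfonyl gives a 4.5-fold higher number from compound 3 to compound 4 (0.65 log units; beyond the scatter) and so moves the number by more than the scatter, although a nitrogen stays on the sulfonyl sulfur. For the compounds shown here, the only earlier step at this sulfur, an at least 12-fold lower number from compound 1 to compound 2 (1.09 log units; beyond the scatter) on replacing methyl, ran towards a lower number, whereas this one runs towards a higher number, which shows that what the sulfonyl nitrogen carries can change the read-out on its own. The single limit among the data says nothing about this step, and nothing else given here accounts for it.

The compounds shown leave open whether the step belongs to the ring or to its hydroxyl, a question that a plain pyrrolidin-1-yl on the sulfonyl sulfur would address. Also open, going by these compounds, is how the opposite configuration at the defined stereocentre, or a ring bearing an amine or a carboxylic acid in place of the hydroxyl, would read in this assay on the same core.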